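This account rests on a few compounds, and the source may have more. Where it says the series, first, only, none or still open, it means among the compounds named here.

Measured so far in an ADME assay on L6 cells (Rattus norvegicus) for cytotoxicity, read by resazurin assay, with a stated time of 72 h; on this read-out lower numbers stand for stronger inhibition and higher numbers for weaker inhibition:

- compound 1 `Cc1occc1C(=O)NC(=O)c1ccccc1O`: 16 ug/mL
- compound 2 `CS(=O)(=O)c1ccc(C(=O)NC(=O)c2ccccc2O)cc1`: > 100 ug/mL (a limit, not a number)
- compound 3 `COC(=O)c1ccc(C(=O)NC(=O)c2ccccc2O)cc1`: 42 ug/mL

Compound 2 has no numerical value in this assay and stands only at its limit of > 100 ug/mL. It is alone there among the three compounds: the limit of > 100 ug/mL in this assay, at which 1 of the 3 values shown sits.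

The next compound is compound 4 `CCN(CC)c1ccc(C(=O)NC(=O)c2ccccc2O)cc1`, which has diethylamino in place of methylsulfonyl on an aromatic carbon, para to a large group (diethylamino in place of methylsulfonyl on an aromatic carbon).

For the measured compounds named here, one measured step bears directly on this change. Replacing the same methylsulfonyl with methoxycarbonyl gives an at least 2.3-fold lower number from compound 2 to compound 3 (0.37 log units; beyond the scatter). This single step lies beyond the scatter, and its true size is open at one end. Compound 1 carries a different group on the other side of the shared core and gives 16 ug/mL, so it offers only a general sense of where numbers fall in this series.

On the evidence of compound 3 at 42 ug/mL, a replacement of the methylsulfonyl is expected to move the number down, towards stronger inhibition. The expected change is an at least 3.3-fold lower number from compound 2 to compound 4 (0.52 log units; beyond the scatter). For compound 4 the estimated value in this assay is 30 ug/mL, with an expected range of 9 ug/mL to 90 ug/mL.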

Compound 4, half-maximal inhibitory concentration: 8.2 ug/mL
The estimate for compound 4 lay 3.7-fold (0.56 log units) above the measured number, and the stated range ends above it.
By their numbers in this assay, from the lowest: compounds 4 and 1 (each within the scatter of the next); then compound 3. At a limit, above all of these: compound 2.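

In this assay, the group on this aromatic carbon, para to a large group, can shift the number well beyond what the methoxycarbonyl swap alone indicated: diethylamino in place of methylsulfonyl gives an at least 12-fold lower number from compound 2 to compound 4 (1.08 log units; beyond the scatter). Diethylamino in place of methoxycarbonyl gives a 5.1-fold lower number from compound 3 to compound 4 (0.71 log units; beyond the scatter), the first step at this position with a measured number at both ends, and it places the three groups in a clear order, with diethylamino lowest, methoxycarbonyl next and methylsulfonyl at the top. Compound 2 remains a limit and not a number, so the true size of each step that starts from it stays open at one end: the limit of > 100 ug/mL in this assay, at which 1 of the 4 values shown sits.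

Whether the lower number goes with the nitrogen or with the two ethyl chains stays open, since the compounds shown include no unsubstituted amine, no dimethylamino group and no all-carbon chain such as butyl at this carbon. Going by these compounds, whether the same order of groups would hold with the group on the other side of the shared core changed, as in compound 1, also remains unknown.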